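The source may report more compounds than this note shows. Statements on the series, on what has been measured and on what is new or still open speak of the compounds shown alone.

Measured compounds in a functional assay on MKN-45 cells (Homo sapiens) for cytotoxicity, read by MTT assay, with a stated time of 48 h; a lower number here means a stronger inhibitor, a higher number a weaker inhibitor:

Compound 1 `COc1cc(-c2nnc(SCc3ccccc3Cl)n2/N=C/c2ccccc2)cc(OC)c1OC` gives > 200000 nM, which is a limit of the assay, not a number.
Compound 2 `COc1ccc(/C=N/n2c(SC)nnc2-c2cc(OC)c(OC)c(OC)c2)c(OC)c1` gives > 200000 nM, a limit of the assay, not a number.
Compound 3 `COc1ccc(/C=N/n2c(SCc3ccc(F)cc3)nnc2-c2cc(OC)c(OC)c(OC)c2)c(OC)c1` gives > 200000 nM, again a limit of the assay, not a number.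

All three values sit at one limit, so compound 3 cannot be placed against compound 1 or compound 2 beyond saying that it shares their limit (the limit of > 200000 nM in this assay, at which 3 of the 3 values shown sit). For the measured compounds named here, the only single-place step measured, a step that the two limits leave unreadable from compound 2 to compound 3, is unreadable because both ends are limits.

Compound 4 `COc1ccc(/C=N/n2c(SCc3ccccc3Cl)nnc2-c2cc(OC)c(OC)c(OC)c2)c(OC)c1` differs from compound 3 in one place: 2-chlorophenyl in place of 4-fluorophenyl on a saturated chain carbon bound to a sulfur. The measured steps give no readable size for any change at this position, and nothing in the series shows a move off the limit. The expectation for compound 4 in this assay is therefore a step of about a number no higher from compound 3 to compound 4 (the limit leaves the size open), that is, no change beyond the scatter, with a further limit the most likely outcome. Compound 4 is estimated at 200000 nM, in the range 60000 nM to 200000 nM.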

Compound 4, half-maximal inhibitory concentration: > 200000 nM
Compound 4 gave a limit, no number; the forecaster's own chance of this, stated with the estimate: 85%; the middle value sits exactly at the limit.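

In this assay compound 4 gives > 200000 nM, which is a limit and not a number. For the compounds shown here, the steps to compound 4 from compound 1, compound 2 and compound 3 cannot be read, so no new step follows: the limit of > 200000 nM in this assay, at which 4 of the 4 values shown sit. Still open, going by these compounds, is whether any group on the saturated chain carbon bound to a sulfur gives a readable number in this assay.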